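This account rests on a few compounds, and the source may have more. Where it says the series, first, only, none or still open, it means among the compounds named here.

In an assay on CHO cells for antagonist activity at transient receptor potential cation channel subfamily V member 1 (Homo sapiens), read by FLIPR (on this read-out higher numbers stand for weaker inhibition and lower numbers for stronger inhibition), compound 1 `CC(C(=O)NCc1ccc(C(F)(F)F)cc1N1CCCC1)c1ccc(NS(C)(=O)=O)c(F)c1` gives 2.3 nM. Compound 2 `CC(C(=O)NCc1ccc(C(F)(F)F)cc1N1CCN(C2CCCCC2)CC1)c1ccc(NS(C)(=O)=O)c(F)c1` carries a 4-cyclohexylpiperazin-1-yl group where compound 1 has pyrrolidin-1-yl; in this assay compound 2 gives 13.8 nM. Among the compounds with values here, of the two numbers known so far, compound 2 therefore stands highest, with compound 1 the only neighbour below it.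

Compound 3 `CC(C(=O)NCc1ccc(C(F)(F)F)cc1OC1CCCC1)c1ccc(NS(C)(=O)=O)c(F)c1` differs from compound 2 in one place: cyclopentyloxy in place of 4-cyclohexylpiperazin-1-yl on an aromatic carbon. Within the data shown here, only one measured step bears on this change, the replacement of pyrrolidin-1-yl by 4-cyclohexylpiperazin-1-yl, which gave a 6.0-fold higher number from compound 1 to compound 2 (0.78 log units; beyond the scatter). Compound 3 removes that same large group again and puts a single small ring at the position, so the expectation is a reversal of most of that step, a fall of about a 3.5-fold lower number from compound 2 to compound 3 (0.54 log units; beyond the scatter) in this assay. For compound 3 the estimated value in this assay is 4 nM, within a range of 1.5 nM to 12 nM.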

Compound 3, inhibition constant: 0.6 nM
Estimate against measurement, compound 3: 6.7-fold (0.82 log units) above, outside the stated range (below it).
By their numbers in this assay, from the lowest: compound 3; then compound 1; then compound 2.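

In this assay, the step of a 23-fold lower number from compound 2 to compound 3 (1.36 log units; beyond the scatter) is the largest seen so far at this position on the aromatic ring, and compound 3 gives the strongest inhibition of the three compounds. Losing the large 4-cyclohexylpiperazin-1-yl group does not account for the whole picture, as the change between two small groups, a 3.8-fold lower number from compound 1 to compound 3 (0.58 log units; beyond the scatter), also lies beyond the scatter. The group at this position therefore matters through more than the presence or absence of the large piperazine, although nothing at hand gives a reason for these differences.

The three compounds cannot separate the contribution of the linking oxygen in cyclopentyloxy from that of its carbon ring. A cyclopentylamino group would address the first, while methoxy or a longer chain such as butoxy would address the second.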